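This account rests on a few compounds, and the source may have more. Where it says the series, first, only, none or still open, it means among the compounds named here.

Measured compounds and values:
Compound 1 `Nc1cc(N)c2nc(-c3ccccc3)c(NCc3ccc(F)cc3)nc2c1`: 8910 nM
Compound 2 `COc1ccc(Sc2nc3cc(N)cc(N)c3nc2-c2ccccc2)cc1`: < 100000 nM (a limit)
Compound 3 `Nc1cc(N)c2nc(-c3ccccc3)c(Sc3ccc(Cl)c(Cl)c3)nc2c1`: 95500 nM

In a functional assay on NCI-H23 cells (Homo sapiens) for inhibition, read by sulforhodamine B assay, with a stated time of 48 h (a higher number here means that more compound is tolerated, a lower number that less compound is tolerated), compound 1 gives 8910 nM and compound 3 gives 95500 nM. For compound 2 this assay yields only a limit, < 100000 nM, which is the limit of < 100000 nM in this assay, at which 1 of the 3 values shown sits. Of the two numbers shown, compound 3 stands highest; its nearest neighbour is compound 1, and the step of an 11-fold higher number from compound 1 to compound 3 (1.03 log units; beyond the scatter) is large and beyond the scatter. The steps a step that the limit leaves unreadable from compound 1 to compound 2 and a step that the limit leaves unreadable from compound 2 to compound 3 cannot be sized, since compound 2 is known only as a limit.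

Compound 4 `Nc1cc(N)c2nc(-c3ccccc3)c(Oc3ccc(F)cc3)nc2c1` differs from compound 3 in one place: 4-fluorophenoxy in place of (3,4-dichlorophenyl)sulfanyl on an aromatic carbon. Among the measured compounds shown here, the only measured step that can be read, the one from compound 1 to compound 3, changed both the linking atom and the aryl group at this position and gave a large rise. Compound 4 keeps an aryl group on a single linking atom, as compound 3 does, but its fluorine-bearing ring resembles the ring of compound 1. The number for compound 4 is therefore expected to fall between those two, with a step of a 2.4-fold lower number from compound 3 to compound 4 (0.38 log units; beyond the scatter). Compound 4 is estimated at 40000 nM, in the range 9000 nM to 100000 nM.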

Compound 4, concentration lethal to 50% of the cells: 77600 nM
Compound 4: middle estimate off by 1.9-fold (0.29 log units), on the low side, and the stated range covers the measured number.
By their numbers in this assay, from the lowest: compound 1; then compounds 4 and 3 (each within the scatter of the next).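

In this assay, 4-fluorophenoxy and (3,4-dichlorophenyl)sulfanyl at this position, next to the ring nitrogen, give a 1.2-fold lower number from compound 3 to compound 4 (0.09 log units; within the scatter), so changing the linking atom and the ring's halogens together leaves no readable difference. Among the compounds shown here, the earlier compounds could not show this, since their only readable step changed the linker and the ring substituents at once. Putting 4-fluorophenoxy in place of (4-fluorobenzyl)amino keeps the same fluorine-bearing ring yet gives an 8.7-fold higher number from compound 1 to compound 4 (0.94 log units; beyond the scatter), so among compounds 1, 3 and 4 the gap follows the link that carries the ring, not the halogens on that ring.

The steps to and from compound 2 cannot be read because compound 2 is known only as a limit: the limit of < 100000 nM in this assay, at which 1 of the 4 values shown sits. Going by these compounds, it also stays open how a phenylamino group or a benzyloxy group would read here, so the part played by the nitrogen of the (4-fluorobenzyl)amino group cannot be separated from that of its extra carbon.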